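The compounds below may be only part of what the source reports. "The series", "measured", "known", "first", "only" and "open" are said of these compounds alone.

Working notes on a series sharing one core. Compound 1 `O=C1C=CCC/C1=C\C(Br)=C\c1ccccc1` gives only a limit in a functional assay on HGC-27 cells (Homo sapiens) for cytotoxicity, read by MTT assay, with a stated time of 72 h (a higher number here means a weaker inhibitor, a lower number a stronger inhibitor), namely > 10000 nM. Compound 2 `O=C1C=CCC/C1=C\C=C\c1ccc(F)cc1` gives 2300 nM in this assay, and compound 3 `COc1cc(/C=C/C=C2\CCC=CC2=O)ccc1O` gives 1200 nM. These two numbers lie within the usual scatter of each other, so compound 2 stands level with compound 3 among the measured numbers, with compound 1 reported as a limit only. Compound 4 `CN(C)c1ccc(/C=C/C=C2\CCC=CC2=O)cc1` differs from compound 2 by dimethylamino in place of fluoro on an aromatic carbon. Among the compounds with values here, no measured pair covers this change, so any expectation rests on the two measured numbers alone. In this assay a small step toward a lower number is expected, a 2.6-fold lower number from compound 2 to compound 4 (0.41 log units; beyond the scatter), scarcely beyond the scatter. Compound 4 is estimated at 900 nM, within 250 nM to 3200 nM.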

Compound 4, half-maximal inhibitory concentration: 1500 nM
Compound 4: middle estimate off by 1.7-fold (0.22 log units), on the low side; the measured number falls inside the stated range.
By their numbers in this assay, from the lowest: compounds 3, 4 and 2 (each within the scatter of the next). At a limit, above all of these: compound 1.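

In this assay, within the data shown here, dimethylamino in place of fluoro on an aromatic carbon, para to a large group, gives a 1.5-fold lower number from compound 2 to compound 4 (0.19 log units; within the scatter) as the first measured step at this position. The larger group leaves the number level with that of the fluoro compound, so this position tolerates the change in this assay. Nothing on hand bears on why the number holds. Open, from the compounds shown here alone, is whether a carboxylic acid, a primary amine or a longer alkyl chain at this position would also leave the number level.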